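The source may hold more compounds than are shown below. What is called first, only, known or untested is meant among the compounds shown, and "the series" means these compounds.

Compound 3 `Cc1oc2ncnc(Nc3cccc(Cl)c3)c2c1C(=O)NCCO` carries a (2-hydroxyethyl)carbamoyl group on the shared core. In a functional assay on MCF7 cells (Homo sapiens) for cytotoxicity, read by MTT assay, with a stated time of 72 h (a lower number here means a stronger inhibitor, a higher number a weaker inhibitor), compound 3 gives only a limit, > 1000000 nM. Compound 1 `CCOC(=O)c1c(C)oc2ncnc(Nc3cccc(Cl)c3)c12`, which has ethoxy on the same carbonyl carbon, also gives only a limit, > 1000000 nM. Both sit at the limit of > 1000000 nM in this assay, at which 2 of the 3 values shown sit, so the step that the two limits leave unreadable from compound 1 to compound 3 cannot be read. Compound 2 `Cc1oc2ncnc(Nc3ccc(OCc4cccc(F)c4)c(Cl)c3)c2c1C(=O)O`, which also bears a carboxy group but differs elsewhere, gives 46000 nM. Compound 4 `Cc1oc2ncnc(Nc3cccc(Cl)c3)c2c1C(=O)O` differs from compound 3 by hydroxy in place of (2-hydroxyethyl)amino on a carbonyl carbon. Going by the values given here, no measured step covers this exchange; compound 2 alone shows that a carboxy group on this core can return a number. Compound 4 is therefore expected to give a step of an at least 3.3-fold lower number from compound 3 to compound 4 (0.52 log units; beyond the scatter), with an estimated value of 300000 nM and a range from 50000 nM to 1500000 nM, and may well return only a limit.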

Compound 4, half-maximal inhibitory concentration: 57500 nM
For compound 4 the middle estimate is 5.2-fold (0.72 log units) above the measured one, within the range that was stated.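

In this assay, hydroxy on the carbonyl carbon gives an at least 17-fold lower number from compound 3 to compound 4 (1.24 log units; beyond the scatter), and it also gives an at least 17-fold lower number from compound 1 to compound 4 (1.24 log units; beyond the scatter), so on this core a number appears with the carboxy group and not with the (2-hydroxyethyl)amino or ethoxy ester forms. Both steps are bounds, and the step between compounds 1 and 3 cannot be read, since those two compounds sit at a limit: the limit of > 1000000 nM in this assay, at which 2 of the 4 values shown sit. Hydrogen in place of (3-fluorobenzyl)oxy gives a 1.3-fold higher number from compound 2 to compound 4 (0.10 log units; within the scatter), so that group makes no readable difference here.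

As far as these compounds go, whether a primary amide or a methyl ester on the carbonyl carbon would also return a number stays open.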